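The source may report more compounds than this note shows. Statements on the series, on what has been measured and on what is new or still open speak of the compounds shown alone.

Of the compounds shown here, three have been measured in an assay on isolated protein for displacement of a labelled ligand from metabotropic glutamate receptor 5 (Homo sapiens), with a stated time of 60 min, tested at 1 uM; a higher number here means more inhibition at the concentration tested (going by the name of the read-out), a lower number less inhibition. Compound 1 `COc1ccc2ncc(S(=O)(=O)c3cccc(C#N)c3)c(N3CCC(C)CC3)c2c1` gives 90%, and compound 3 `Cc1cc(C)cc(S(=O)(=O)c2cnc3cc(F)ccc3c2N2CCC(C)CC2)c1` gives 80%. Compound 2 `CC1CCN(c2c(S(=O)(=O)c3ccc(F)cc3)cnc3c(F)cccc23)CC1` gives 26%, the lowest of the three, with the other two numbers lying beyond the scatter above it. Compound 4 `CC1CCN(c2c(S(=O)(=O)c3ccc(Cl)c(Cl)c3)cnc3c(F)cccc23)CC1` has not yet been measured. Relative to compound 2 it carries 3,4-dichlorophenyl in place of 4-fluorophenyl on a sulfonyl sulfur. Among the compounds with values here, no two measured compounds differ in one place only, so the effect of this change has no measured counterpart, and compound 1 and compound 3 differ from compound 2 in their cores as well as in the group on the sulfonyl sulfur. A rise beyond the scatter is nonetheless expected, estimated as a step of a number 29 percentage points higher from compound 2 to compound 4 (beyond the scatter) in this assay. For compound 4 the expected value is 55%, within a range from 25% to 85%.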

Compound 4, a percentage reported as inhibition, at one concentration (the size of the read-out at that concentration, not a potency): 95%
The estimate for compound 4 lay 40 percentage points below the measured number; the measured number lies above the stated range.
By their numbers in this assay, from the lowest: compound 2; then compounds 3, 1 and 4 (each within the scatter of the next, the first and the last beyond it).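

In this assay, within the data shown here, swapping 3,4-dichlorophenyl for 4-fluorophenyl on a sulfonyl sulfur gives a number 69 percentage points higher from compound 2 to compound 4 (beyond the scatter) and provides the first comparison here in which only one place differs. It shows that this position alone can strongly change the read-out, with the core held constant. Nothing measured here explains the rise.

From the compounds shown here alone, it remains open whether both chlorine atoms are needed, and how an amine or a carboxylic acid on this phenyl ring would behave.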